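A few compounds are considered here, and "the series" means these few. Any claim that something is new, unique, unknown or untested is made for them only; others in the source may bear on it.

In a functional assay on NCI-H460 cells (Homo sapiens) for cytotoxicity, read by MTT assay, with a stated time of 72 h (on this read-out lower numbers stand for stronger inhibition and higher numbers for weaker inhibition), three compounds of one shared core have been measured. Compound 1 `CN(C)CCn1cnnc1-c1cc(Oc2ccc(NC(=O)N/N=C/c3c(Cl)cccc3Cl)cc2F)ccn1` gives 350 nM, compound 2 `CN(C)CCn1cnnc1-c1cc(Oc2ccc(NC(=O)N/N=C/c3cccc(Br)c3)cc2F)ccn1` gives 520 nM, and compound 3 `CN(C)CCn1cnnc1-c1cc(Oc2ccc(NC(=O)N/N=C/c3ccc(O)c(F)c3)cc2F)ccn1` gives 2620 nM. Compound 3 stands highest of the three: the step of a 7.5-fold higher number from compound 1 to compound 3 (0.87 log units; beyond the scatter) and the step of a 5.0-fold higher number from compound 2 to compound 3 (0.70 log units; beyond the scatter) both lie beyond the scatter, whereas the step of a 1.5-fold higher number from compound 1 to compound 2 (0.17 log units; within the scatter) stays within it. Compound 3 is therefore the weakest of the measured set in this assay.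

Compound 4 `COc1cc(/C=N/NC(=O)Nc2ccc(Oc3ccnc(-c4nncn4CCN(C)C)c3)c(F)c2)ccc1O` departs from compound 3 by one change: methoxy in place of fluoro on an aromatic carbon. Among the compounds with values here, no measured pair exchanges a fluoro for a methoxy at this position, so nothing directly tests this move. What the steps from compound 1 and from compound 2 to compound 3 show is that the aryl group on the carbon with a double bond to nitrogen shifts the number by a modest amount, so a step of at most similar size, in either direction, would be unsurprising, and a step within the scatter is as likely as any. On that basis compound 4 is expected to give about 2500 nM in this assay, with a range from 800 nM to 8000 nM, which would mean an estimated step of a 1.0-fold lower number from compound 3 to compound 4 (0.02 log units; within the scatter).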

Compound 4, half-maximal inhibitory concentration: 57 nM
Beside the measured number, compound 4's estimate is 44-fold (1.64 log units) above it, outside the stated range (below it).
By their numbers in this assay, from the lowest: compound 4; then compounds 1 and 2 (each within the scatter of the next); then compound 3.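

In this assay, within the data shown here, the exchange of fluoro for methoxy on an aromatic carbon ortho to a hydroxy group gives a 46-fold lower number from compound 3 to compound 4 (1.66 log units; beyond the scatter) and is the only large step in the set, so this one position on the aryl group moves the number far more than the earlier exchanges of whole aryl groups suggested. The 4-hydroxy-3-methoxyphenyl group also lies beyond the scatter of both halogen-only aryl groups, with a 9.1-fold lower number from compound 2 to compound 4 (0.96 log units; beyond the scatter) and a 6.1-fold lower number from compound 1 to compound 4 (0.79 log units; beyond the scatter) as its steps, and compound 3 and compound 4 both carry the hydroxy group yet stand at opposite ends of the order, so the hydroxy group alone does not set the weak end of the series. No accompanying measurement bears on this result, and the size of the step remains unexplained.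

The compounds shown leave open whether the step is particular to methoxy or would also appear with an ethoxy group, a methyl group or a plain hydrogen at this position. They also leave open whether methoxy would give the same result if the neighbouring hydroxy group were replaced by an amine or a second methoxy group.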